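Swapping a Cyclopropyl for a Propyl Chain

This account rests on a few compounds, and the source may have more. Where it says the series, first, only, none or still open, it means among the compounds named here.

The measured compounds:
compound 1, `CCCCCCCc1cnc(-c2ccc(CNC(=O)[C@H]3NCC[C@@H]3O)cc2)s1`, 70 nM
compound 2, `O=C(NCc1ccc(-c2noc(CCC3CC3)n2)cc1)[C@H]1NCC[C@@H]1O`, 5000 nM
compound 3, `CCCCCCCc1nc(-c2ccc([C@@H](NC(=O)[C@H]3NCC[C@@H]3O)C(C)C)cc2)no1`, 110 nM

All three were tested in an assay on isolated protein for inhibition of sphingosine kinase 1 (Homo sapiens); on this read-out higher numbers stand for weaker inhibition and lower numbers for stronger inhibition. Compound 2 stands at the top of the three numbers, which here means the weakest inhibition of the set. The gap between compound 2 and compound 3 is well beyond the usual scatter. The gap between compound 2 and compound 1 is well beyond the usual scatter as well, and compound 2 is clearly apart from the other two.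

Compound 4, `CCCCCc1nc(-c2ccc(CNC(=O)[C@H]3NCC[C@@H]3O)cc2)no1`, has not yet been measured. It differs from compound 2 in one place: propyl in place of cyclopropyl on a saturated chain carbon, two bonds along the chain from an aromatic carbon. Among the compounds with values here, no pair of measured compounds tells directly what this exchange does. Compound 1 and compound 3 both carry a long straight chain at the end of the molecule and give the two lower numbers, but they also differ from compound 2 elsewhere, so their values only hint that a straight chain may go along with stronger inhibition.

On that hint, compound 4 is expected to give a moderately lower number than compound 2, a step of a 3.3-fold lower number from compound 2 to compound 4 (0.52 log units; beyond the scatter). The estimate for compound 4 in this assay is 1500 nM, with a likely range from 400 nM to 6000 nM.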

Compound 4, half-maximal inhibitory concentration: 430 nM
Beside the measured number, compound 4's estimate is 3.5-fold (0.54 log units) above it, and the stated range covers the measured number.
By their numbers in this assay, from the lowest: compounds 1 and 3 (each within the scatter of the next); then compound 4; then compound 2.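

In this assay, exchanging cyclopropyl for propyl on a saturated chain carbon, two bonds along the chain from an aromatic carbon, gives a 12-fold lower number from compound 2 to compound 4 (1.07 log units; beyond the scatter) as a large step beyond the scatter. Within the data shown here, this is the first direct reading of the exchange, free of the other structural differences that set compound 1 and compound 3 apart from compound 2. Both groups have the same count of carbons, and neither has any hydrogen-bond donors, hydrogen-bond acceptors or net charge, so the visible difference is that one has a three-membered ring and the other has no ring, and this small edit clearly matters for inhibition at this position. Nothing available explains why the open chain goes with the lower number.

A single pair cannot show whether any ring at this place would give a high number or whether the result is specific to cyclopropyl, and a cyclobutyl group would help to separate those two possibilities. It also leaves open how a branched isopropyl group, or a longer chain such as hexyl on the same core, would compare with propyl.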